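From Methoxy to Isopropyl on the Pendant Aryl Ring

This account rests on a few compounds, and the source may have more. Where it says the series, first, only, none or still open, it means among the compounds named here.

Measured in a functional assay on NCI-H2122 cells (Homo sapiens) for inhibition, read by microscopy, with a stated time of 10 days; on this read-out higher numbers stand for weaker inhibition and lower numbers for stronger inhibition:
Compound 1, `Cn1nc(-c2ccccc2)c2c1OC(N)=C(C#N)C2c1cc(F)cc(F)c1`, gives 6600 nM.
Compound 2, `COc1ccc(C2C(C#N)=C(N)Oc3c2c(-c2ccccc2)nn3C)cc1`, gives > 10000 nM.
Compound 3, `COc1ccc(C2C(C#N)=C(N)Oc3c2c(-c2ccccc2)nn3-c2ccccc2)cc1`, gives 3100 nM.

The value of compound 2 is a limit of this assay, not a number, so compound 2 stands only at the limit of > 10000 nM in this assay, at which 1 of the 3 values shown sits. Compound 4, `CC(C)c1ccc(C2C(C#N)=C(N)Oc3c2c(-c2ccccc2)nn3C)cc1`, has not yet been measured; it differs from compound 2 by isopropyl in place of methoxy on an aromatic carbon. Two measured steps exist. The step of an at least 1.5-fold higher number from compound 1 to compound 2 (0.18 log units; that floor lies within the scatter) changes the same pendant aryl ring and stays within the scatter. The step of an at least 3.2-fold lower number from compound 2 to compound 3 (0.50 log units; beyond the scatter) changes the methyl on the aromatic nitrogen, a different place, and is beyond the scatter, but that nitrogen is untouched in compound 4. Nothing measured here shows what methoxy against isopropyl does on this ring, so no step beyond the scatter is expected in this assay, and compound 4 may again come back as a limit. Compound 4 is estimated at 10000 nM, within 4000 nM to 30000 nM, which would be a step of a number no higher from compound 2 to compound 4 (the limit leaves the size open).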

Compound 4, half-maximal inhibitory concentration: 5400 nM
The estimate for compound 4 lay 1.9-fold (0.27 log units) above the measured number; low and high end bracket the measured number.
By their numbers in this assay, from the lowest: compounds 3, 4 and 1 (each within the scatter of the next, the first and the last beyond it). At a limit, above all of these: compound 2.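

In this assay, among the compounds shown here, the change from methoxy to isopropyl on the pendant aryl ring gives an at least 1.8-fold lower number from compound 2 to compound 4 (0.26 log units; that floor lies within the scatter), the first direct reading of a change in this group, though it fixes only a floor for the size of the step. Compound 2 stands at a limit of the assay rather than at a number: the limit of > 10000 nM in this assay, at which 1 of the 4 values shown sits. Comparing the two aryl groups gives a 1.2-fold lower number from compound 1 to compound 4 (0.09 log units; within the scatter), so with methyl on the aromatic nitrogen, 4-isopropylphenyl and 3,5-difluorophenyl cannot be told apart.

From the compounds shown here alone, whether phenyl in place of that methyl would lower the number for the isopropyl compound, as it does for the methoxy pair, remains open. Also open, going by these compounds, is what a tert-butyl group, a dimethylamino group or a carboxylic acid would give in the place of isopropyl.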